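Extending a Side Chain on Two Related Cores

The source may hold more compounds than are shown below. What is called first, only, known or untested is meant among the compounds shown, and "the series" means these compounds.

The series rests on two cores that carry the same amide-linked aryl portion. Compound 1 `CCCCSc1nc(C(C)(C)C)ccc1CNC(=O)C(C)c1ccc(NS(C)(=O)=O)c(F)c1` and compound 2 `CCCCCCSc1nc(C(C)(C)C)ccc1CNC(=O)C(C)c1ccc(NS(C)(=O)=O)c(F)c1` share one core; compound 3 `CCCCOc1cc(C(C)(C)C)ccc1CNC(=O)C(C)c1ccc(NS(C)(=O)=O)c(F)c1` and the as-yet unmeasured compound 4 `CCCCCCOc1cc(C(C)(C)C)ccc1CNC(=O)C(C)c1ccc(NS(C)(=O)=O)c(F)c1` share the other. The difference between the two cores is not broken down here.

In an assay on cells for antagonist activity at transient receptor potential cation channel subfamily V member 1 (Homo sapiens), read by FLIPR and calcium flux, with a stated time of 6 min (on this read-out lower numbers stand for stronger inhibition and higher numbers for weaker inhibition), compound 1 gives 3.2 nM, while compound 2 gives 1.5 nM. The change between them, (ethyl in place of hydrogen on a saturated chain carbon, four bonds along the chain from a sulfur), brought a 2.1-fold lower number from compound 1 to compound 2 (0.33 log units; beyond the scatter). Compound 3 gives 1.4 nM in this assay, close to the number for compound 2 and distinctly below that of compound 1.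

Compound 4 carries the same kind of change as compound 2, namely (ethyl in place of hydrogen on a saturated chain carbon, four bonds along the chain from an oxygen on an aromatic ring); here the chain hangs from an oxygen on an aromatic ring rather than from a sulfur. The expectation for compound 4 is therefore a step of a 1.8-fold lower number from compound 3 to compound 4 (0.24 log units; within the scatter) in this assay, modelled on the step from compound 1 to compound 2, with wide uncertainty because only a 2.1-fold lower number from compound 1 to compound 2 (0.33 log units; beyond the scatter) supports it. The estimated value for compound 4 is 0.8 nM, expected to lie between 0.35 nM and 2 nM.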

Compound 4, inhibition constant: 0.5 nM
Beside the measured number, compound 4's estimate is 1.6-fold (0.20 log units) above it, within the range that was stated.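

In this assay, ethyl in place of hydrogen on a saturated chain carbon, four bonds along the chain from an oxygen on an aromatic ring, gave a 2.8-fold lower number from compound 3 to compound 4 (0.45 log units; beyond the scatter) and so lowered the number on this core as well. The change therefore carried from the core of compound 1 to the core of compound 3 in direction, and the two steps do not differ in size beyond what repeated measurements would allow: the same change on two cores in this assay, a 2.1-fold lower number (0.33 log units; beyond the scatter) from compound 1 to compound 2 and a 2.8-fold lower number (0.45 log units; beyond the scatter) from compound 3 to compound 4, 1.3-fold (0.12 log units) apart, within the scatter of two such steps. Among the compounds shown here, this rests on only two pairs in a single assay, so it shows that the step held on these two cores, but not that it would hold on a third core, and it gives no explanation for the lower numbers.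

The compounds shown leave open whether a longer chain on either core would lower the number further, or whether a chain ending in an amine or a carboxylic acid would be tolerated. They also do not separate the sulfur from the oxygen, since the two cores differ in more than one place.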